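Replacing the 4-methylpiperazin-1-yl Group of Compound 2

The compounds below may be only part of what the source reports. "The series", "measured", "known", "first", "only" and "open" are said of these compounds alone.

Three compounds have been measured in an assay on isolated protein for inhibition of NUAK family SNF1-like kinase 2 (Homo sapiens), read by ADP-Glo, with a stated time of 60 min, tested at 10 uM, in the presence of a further agent that is not named here; a higher number here means more inhibition at the concentration tested (going by the name of the read-out), a lower number less inhibition:

Compound 1, `CCC(=O)Nc1cccc(Oc2ccnc(Nc3ccc(N4CCN(C)CC4)cc3)n2)c1`, gives 48.8%.
Compound 2, `CCC(=O)Nc1cccc(Oc2nc(Nc3ccc(N4CCN(C)CC4)cc3)ncc2Cl)c1`, gives 82.6%.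
Compound 3, `CCC(=O)Nc1cccc(Oc2nc(Nc3ccc(N4CCN(C)CC4)cc3Cl)ncc2Cl)c1`, gives 69.1%.

Compound 2 stands highest of the three numbers in this assay. Compound 3 is nearest to it, and compound 1 is furthest from it. Both measured steps are chloro in place of hydrogen on an aromatic carbon: a number 33.8 percentage points higher from compound 1 to compound 2 (beyond the scatter), and a number 13.5 percentage points lower from compound 2 to compound 3 (beyond the scatter).

Compound 4, `CCC(=O)Nc1cccc(Oc2nc(Nc3ccc(N4CCCCC4)cc3)ncc2Cl)c1`, has not yet been measured in this assay. It differs from compound 2 at one place: piperidin-1-yl in place of 4-methylpiperazin-1-yl on an aromatic carbon. Neither measured step bears on this change, since both concern chloro in place of hydrogen and leave the 4-methylpiperazin-1-yl group untouched. The two chloro-bearing positions of compound 2 are kept in compound 4, so the number of compound 2 is the natural point of reference. Going by the values given here, with no step of this kind on record, a change within the scatter, in either direction, is expected for compound 4, which means an expected step of a number 8.6 percentage points lower from compound 2 to compound 4 (within the scatter). Compound 4 is therefore estimated at 74% in this assay, with a range from 50% to 92%.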

Compound 4, a percentage reported as inhibition, at one concentration (the size of the read-out at that concentration, not a potency): 72.3%
The estimate for compound 4 lay 1.7 percentage points above the measured number, and the stated range covers the measured number.
By their numbers in this assay, from the lowest: compound 1; then compounds 3 and 4 (each within the scatter of the next); then compound 2.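

In this assay, compound 1, compound 2 and compound 3 all carry the 4-methylpiperazin-1-yl group, so only compound 4 tests this position, and replacing that group with piperidin-1-yl gives a number 10.3 percentage points lower from compound 2 to compound 4 (beyond the scatter). The position therefore responds to this change, but the 4-methylpiperazin-1-yl group is not required for a sizeable reading: with one six-membered non-aromatic ring holding 1 hetero atom in place of 2, compound 4 still gives 72.3% at the one concentration tested. Nothing on record explains why this exchange lowers the number.

The compounds shown leave open which part of the 4-methylpiperazin-1-yl group matters, the methyl or the second ring nitrogen, as the change to piperidin-1-yl removes both at once. A piperazin-1-yl group with a hydrogen in place of the methyl, a morpholin-4-yl group with an oxygen in place of the methyl-bearing nitrogen, or an open-chain dimethylamino group at this position would each bear on that question.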